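This account rests on a few compounds, and the source may have more. Where it says the series, first, only, none or still open, it means among the compounds named here.

Compound 3 `CC(C)c1cccc(C(C)C)c1OS(=O)(=O)NC(=O)Oc1ccc(F)cc1` is one of the aryl carbamates of the shared core. In an assay on liver for inhibition of sterol O-acyltransferase 1 (Rattus norvegicus), using microsomes (on this read-out higher numbers stand for weaker inhibition and lower numbers for stronger inhibition), compound 3 is reported only as a limit, > 50000 nM. Compound 2 `CC(C)c1cccc(C(C)C)c1OS(=O)(=O)NC(=O)Oc1cccnc1` likewise sits at a limit in this assay, > 50000 nM. Going by the values given here, compound 1 `CCC(C)N(C(=O)NS(=O)(=O)Oc1c(C(C)C)cccc1C(C)C)C(C)CC` is the only member with a number, 12000 nM in this assay, and the steps of an at least 4.1-fold higher number from compound 1 to compound 2 (0.61 log units; beyond the scatter) and an at least 4.1-fold higher number from compound 1 to compound 3 (0.61 log units; beyond the scatter) both run into the limit described by the limit of > 50000 nM in this assay, at which 2 of the 3 values shown sit. Compound 4 `Cc1cccc(C)c1OC(=O)NS(=O)(=O)Oc1c(C(C)C)cccc1C(C)C` differs from compound 3 by 2,6-dimethylphenyl in place of 4-fluorophenyl on an oxygen next to a carbonyl group. Among the compounds with values here, the only measured change at this oxygen, a step that the two limits leave unreadable from compound 2 to compound 3, gives no readable size, so no step beyond the scatter is expected for the move to compound 4. The estimate for compound 4 in this assay is 45000 nM, within 15000 nM to 150000 nM. The expected step is an at least 1.1-fold lower number from compound 3 to compound 4 (0.04 log units; that floor lies within the scatter).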

Compound 4, half-maximal inhibitory concentration: > 50000 nM
Compound 4: no number, only a limit; the forecaster's own chance of this, stated with the estimate: 65%; middle value at least 1.1-fold (0.04 log units) from the limit.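

With 2,6-dimethylphenoxy on the carbonyl carbon, a third aryl carbamate gives only a limit in this assay, so neither the fluorine nor the pyridine nitrogen is needed for this outcome: the limit of > 50000 nM in this assay, at which 3 of the 4 values shown sit. The steps among compound 2, compound 3 and compound 4 cannot be read. Bis(sec-butyl)amino remains the only group here with a number, and its replacement gives an at least 4.1-fold higher number from compound 1 to compound 4 (0.61 log units; beyond the scatter).

Where the aryl carbamates truly lie beyond the limit stays open. Also open, on these data alone, is how a smaller amine such as diethylamino or piperidine compares with compound 1 at 12000 nM.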